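Ethoxysulfonyl in Place of Cyano on the Shared Core

The source may report more compounds than this note shows. Statements on the series, on what has been measured and on what is new or still open speak of the compounds shown alone.

Compound 1 `O=Cc1ccc(-c2cnc(C(=O)CCCCCCc3ccccc3)o2)nc1` gives 2.2 nM in an assay for inhibition of Fatty-acid amide hydrolase 1 (Rattus norvegicus), using a Dixon plot; on this read-out lower numbers stand for stronger inhibition and higher numbers for weaker inhibition.
Compound 2 `N#C/C=C/c1ccc(-c2cnc(C(=O)CCCCCCc3ccccc3)o2)nc1` gives 2.1 nM in this assay.

Compound 2 has the lowest of the two numbers, but its nearest neighbour is compound 1, and the step of a 1.0-fold lower number from compound 1 to compound 2 (0.02 log units; within the scatter) is within the scatter, so the two compounds cannot be put in order on this assay.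

Compound 3 `CCOS(=O)(=O)/C=C/c1ccc(-c2cnc(C(=O)CCCCCCc3ccccc3)o2)nc1` has not yet been measured. It differs from compound 2 in one place: ethoxysulfonyl in place of cyano on a double-bonded chain carbon bound to a double-bonded chain carbon. Among the measured compounds shown here, only one measured step bears on this change, a 1.0-fold lower number from compound 1 to compound 2 (0.02 log units; within the scatter), which exchanged formyl for 2-cyanoethenyl on an aromatic carbon and stayed within the scatter. For the measured compounds named here, no measured pair shows an ethoxysulfonyl group on a chain carbon, so the expectation rests on that single step, which suggests that this part of the molecule tolerates exchange without a shift beyond the scatter. Compound 3 is therefore expected to give about 3 nM in this assay, with a range from 1 nM to 10 nM. The expected step is a 1.4-fold higher number from compound 2 to compound 3 (0.15 log units; within the scatter), with no direction claimed beyond the scatter.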

Compound 3, inhibition constant: 2.1 nM
For compound 3 the middle estimate is 1.4-fold (0.15 log units) above the measured one, and the stated range covers the measured number.
By their numbers in this assay, from the lowest: compounds 2, 3 and 1 (each within the scatter of the next).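

In this assay, ethoxysulfonyl, with 6 heavy atoms and 3 hydrogen-bond acceptors, replaces cyano, with 2 heavy atoms and 1 hydrogen-bond acceptor, on a double-bonded chain carbon bound to a double-bonded chain carbon, and the result is no change at the digits printed from compound 2 to compound 3 (within the scatter) in this first measured exchange at that carbon. The wider exchange on the aromatic carbon, 2-(ethoxysulfonyl)ethenyl in place of formyl, gives a 1.0-fold lower number from compound 1 to compound 3 (0.02 log units; within the scatter) and so also stays inside the scatter, which leaves compounds 1, 2 and 3 without an order on this read-out and shows that, among these three compounds, the number stays within the scatter across substituents that differ this much in atom count. Nothing available on these compounds accounts for this flat result.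

As far as these compounds go, whether it would hold for an amine or a carboxylic acid at this chain carbon, or for a longer chain carrying the ethoxysulfonyl group, remains open. All three compounds also share the same core, so whether the result depends on the rest of the molecule is unresolved as well.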